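A few compounds are considered here, and "the series" means these few. Any claim that something is new, unique, unknown or untested is made for them only; others in the source may bear on it.

Working notes on the thiocarbamate series.

Compound 1 `S=C(Nc1cccc(Cl)c1)OCCc1ccccn1` and compound 2 `Cc1ccc(NC(=S)OCCc2ccccn2)cc1Cl` share one core; compound 3 `S=C(Nc1ccccc1)OCCc1ccccc1` and compound 4 `Cc1ccc(NC(=S)OCCc2ccccc2)cc1` share another. The difference between the two cores is not broken down here. In an ADME assay on MT4 cells (Homo sapiens) for cytotoxicity, read by MTT assay (a lower number here means that less compound is tolerated, a higher number that more compound is tolerated), compound 1 gives 47000 nM, compound 2 gives 59000 nM and compound 3 gives 100000 nM.

The change from compound 1 to compound 2 is methyl in place of hydrogen on an aromatic carbon, and it gave a 1.3-fold higher number from compound 1 to compound 2 (0.10 log units; within the scatter). The change from compound 3 to compound 4 is methyl in place of hydrogen on an aromatic carbon. It is the same kind of change, but not the same: in the first pair the entering methyl sits ortho to a chloro group and para to a large group, while in compound 4 it sits para to a large group on a ring that carries nothing else.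

In this assay, within the data shown here, the step from compound 3 to compound 4 is expected to be small, about a 1.2-fold higher number from compound 3 to compound 4 (0.06 log units; within the scatter), because the one measured step of this kind, a 1.3-fold higher number from compound 1 to compound 2 (0.10 log units; within the scatter), stayed within the scatter. Compound 4 is therefore estimated at 115000 nM, with a range from 60000 nM to 220000 nM; the value of compound 3 may itself lie near the top of what this assay reports, so a limit rather than a number is possible.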

Compound 4, half-maximal cytotoxic concentration: > 100000 nM
Compound 4 was reported as a limit (the forecaster's own chance of this, stated with the estimate: 35%); the middle value does not contradict the limit.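

In this assay compound 4 is reported as a limit, > 100000 nM, and not as a number; the size of the step that ends at compound 4 cannot be read. Methyl in place of hydrogen on an aromatic carbon gives a number no lower from compound 3 to compound 4 (the limit leaves the size open), which is all the comparison shows, and whether this step differs from the one on the other core stays undecided: the same change on two cores in this assay, a 1.3-fold higher number (0.10 log units; within the scatter) from compound 1 to compound 2 and a number no lower (the limit leaves the size open) from compound 3 to compound 4; the limit leaves it open whether they differ. The result therefore does not show that the change carries across cores with the same size, and the second core offers only a read-out that ends at a limit: the limit of > 100000 nM in this assay, at which 1 of the 4 values shown sits.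

The compounds shown leave open what an amine or a carboxylic acid in place of the methyl would do on either core, and what a longer chain in the link to the far ring would do. On the core of compound 3, a readable step would need a compound whose value falls short of the limit.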